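Methoxy on the Anilino Ring: Cytotoxicity in Vero Cells

The compounds below may be only part of what the source reports. "The series", "measured", "known", "first", "only" and "open" are said of these compounds alone.

Compound 1 `CC(=O)C[C@H]1O[C@@H](On2cc(CN3C(=O)/C(=N\Nc4ccccc4)c4ccccc43)nn2)[C@H](OC(C)=O)[C@@H](OC(C)=O)[C@@H]1OC(C)=O` and compound 2 `COc1ccc(N/N=C2\C(=O)N(Cc3cn(O[C@@H]4O[C@H](CC(C)=O)[C@@H](OC(C)=O)[C@H](OC(C)=O)[C@H]4OC(C)=O)nn3)c3ccccc32)cc1` share a core that carries a fully acetylated sugar. In an ADME assay on Vero cells (Chlorocebus sabaeus) for cytotoxicity, read by fluorescence and resazurin assay, with a stated time of 3 days (on this read-out lower numbers stand for higher toxicity in this test and higher numbers for lower toxicity in this test), compound 1 gives 108000 nM, and compound 2 gives 95300 nM. The change between them is methoxy in place of hydrogen on an aromatic carbon and it made a 1.1-fold lower number from compound 1 to compound 2 (0.05 log units; within the scatter).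

Compound 3 `O=C1/C(=N\Nc2ccccc2)c2ccccc2N1Cc1cn(O[C@@H]2O[C@H](CO)[C@@H](O)[C@H](O)[C@H]2O)nn1` carries the free sugar instead; the difference between its core and the core of compound 1 is not broken down here. In this assay compound 3 gives 88500 nM, a number within the usual scatter of those of compound 1 and compound 2.

Compound 4 `COc1ccc(N/N=C2\C(=O)N(Cc3cn(O[C@@H]4O[C@H](CO)[C@@H](O)[C@H](O)[C@H]4O)nn3)c3ccccc32)cc1` is compound 3 with the same change already seen between compound 1 and compound 2: methoxy in place of hydrogen on an aromatic carbon. Because that change gave only a 1.1-fold lower number from compound 1 to compound 2 (0.05 log units; within the scatter), a step of similar size is expected here, namely a 1.1-fold lower number from compound 3 to compound 4 (0.03 log units; within the scatter). For compound 4 in this assay the estimate is 82000 nM, with a likely range from 45000 nM to 150000 nM.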

Compound 4, half-maximal cytotoxic concentration: 79600 nM
For compound 4 the middle estimate is 1.0-fold (0.01 log units) above the measured one; the range from low to high includes it.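

In this assay, methoxy in place of hydrogen on an aromatic carbon gave a 1.1-fold lower number from compound 3 to compound 4 (0.05 log units; within the scatter). Set beside the earlier step, the change reads the same whether the shared core carries the fully acetylated sugar or the free sugar: the same change on two cores in this assay, a 1.1-fold lower number (0.05 log units; within the scatter) from compound 1 to compound 2 and a 1.1-fold lower number (0.05 log units; within the scatter) from compound 3 to compound 4, 1.0-fold (0.01 log units) apart, within the scatter of two such steps. Among the compounds shown here, each step lies within the scatter, which means that this agreement shows only that the change gave no readable shift on either core; it does not show a real small lowering of the number, nor that the change would behave the same way on any core beyond these two.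

The compounds shown leave open whether a different group on that aromatic carbon, such as an amine, a carboxylic acid or a longer chain like ethoxy, would give a step beyond the scatter. They also leave open what methoxy does on another carbon of the same ring, and how this change reads outside this assay.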